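A few compounds are considered here, and "the series" means these few. Any claim that something is new, unique, unknown or untested is made for them only; others in the source may bear on it.

In a functional assay on L1210 cells (Mus musculus) for cytotoxicity, read by MTT assay, with a stated time of 24 h (on this read-out higher numbers stand for weaker inhibition and lower numbers for stronger inhibition), compound 1 `COc1cc(C(=O)/C=C/c2ccc(C)cc2)cc(OC)c1OC` gives 50500 nM. Compound 2 `COc1cc(C(=O)/C=C/c2ccc(Br)cc2)cc(OC)c1OC` gives no number, only a limit, > 100000 nM. For the measured compounds named here, the one measured step is bromo in place of methyl on an aromatic carbon, an at least 1.9-fold higher number from compound 1 to compound 2 (0.29 log units; that floor lies within the scatter). It ends at the limit of > 100000 nM in this assay, at which 1 of the 2 values shown sits, so it is a floor and not a size.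

Compound 3 `COc1cc(C(=O)/C=C/c2ccc([N+](=O)[O-])cc2)cc(OC)c1OC` follows from compound 2 by one change, nitro in place of bromo on an aromatic carbon, para to a large group. Going by the values given here, only the step of an at least 1.9-fold higher number from compound 1 to compound 2 (0.29 log units; that floor lies within the scatter) bears on this change, and it involves no nitro group, so it offers no definite size to carry over. Compound 1, at 50500 nM, shows that a number can be read in this series, and a measurable value close to that of compound 1 is therefore expected in this assay. The expected change is modest and would run toward a lower number, though it may not exceed the scatter, and the estimate is an at least 1.5-fold lower number from compound 2 to compound 3 (0.18 log units; that floor lies within the scatter). For compound 3 the estimated value is 65000 nM, with an expected range of 20000 nM to 120000 nM.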

Compound 3, half-maximal inhibitory concentration: > 100000 nM
Compound 3: only a limit was reported; the forecaster's own chance of this, stated with the estimate: 40%; middle value at least 1.5-fold (0.18 log units) away from the limit.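

Compound 3 gives no number in this assay, only a limit, > 100000 nM. This is a second replacement of the methyl group at this place, para to a large group, and it gives an at least 1.9-fold higher number from compound 1 to compound 3 (0.29 log units; that floor lies within the scatter), so nitro, like bromo, yields only a floor when set against methyl, and that floor does not go beyond the scatter. Compounds 2 and 3 both rest on limits, so the step between them cannot be read, and methyl remains the only group at this place with a readable value, which makes the series more limited than compound 1 alone suggested: the limit of > 100000 nM in this assay, at which 2 of the 3 values shown sit.

The compounds shown leave open how far compound 2 and compound 3 lie past their limits, and therefore whether bromo, nitro and methyl truly differ at this place by more than the scatter. They also leave open whether an amine, a hydroxyl group or a carboxylic acid at the same place on the shared core would give a readable number.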